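Phenyl for pyridinyl on a weakly cytotoxic diaryl core

This account rests on a few compounds, and the source may have more. Where it says the series, first, only, none or still open, it means among the compounds named here.

Four compounds share one core. Compound 1 `Oc1cccc(-c2cc(-c3cccnc3)nc(-c3cccc(Cl)c3)c2)c1` and compound 2 `Oc1cccc(-c2cc(-c3cccnc3)nc(-c3ccccc3Cl)c2)c1` carry a 3-chlorophenyl or a 2-chlorophenyl group, and compound 3 `Oc1cccc(-c2cc(-c3ccc(Cl)cc3)nc(-c3cccnc3)c2)c1` carries a 4-chlorophenyl group beside the pyridin-3-yl and 3-hydroxyphenyl groups. In a functional assay on DU-145 cells (Homo sapiens) for cytotoxicity, read by CCK-8 assay and cell counting, with a stated time of 2 days (a higher number here means a weaker inhibitor, a lower number a stronger inhibitor), compound 3 gives 26800 nM, a weak result. In this assay compound 2 gives "not determined" (no result reported), and compound 1 likewise gives "not determined" (no result reported), so no measured step between any two of these compounds exists.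

Compound 4 `Oc1cccc(-c2cc(-c3ccccc3)nc(-c3ccccc3Cl)c2)c1` differs from compound 2 in one place: phenyl in place of pyridin-3-yl on an aromatic carbon. From the compounds shown here alone, with no number for compound 2 and only compound 3 measured, the size of this step is unknown; the one result on file points to weak inhibition across the series, and the change is not expected to move the value beyond the scatter in either direction. Compound 4 is therefore estimated at 30000 nM in this assay, within a range from 8000 nM to 100000 nM.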

Compound 4, half-maximal inhibitory concentration: 1480 nM
For compound 4 the middle estimate is 20-fold (1.31 log units) above the measured one; the measured number lies below the stated range.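

In this assay, among the compounds shown here, compound 4 gives 1480 nM but compound 2 has no single number, so no step between compound 2 and compound 4 can be read. From the compounds shown here alone, whether phenyl in place of pyridin-3-yl changes the value remains open. No evidence on hand bears on this result.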